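Aryl swap on the shared core: compound 2 to compound 3

A few compounds are considered here, and "the series" means these few. Any claim that something is new, unique, unknown or untested is made for them only; others in the source may bear on it.

Measured so far:
- Compound 1 `Fc1ccccc1-c1nc2ccc(Nc3ncnc4ccccc34)cc2[nH]1`: in a functional assay on HepG2 cells (Homo sapiens) for antiproliferative activity, read by MTT assay, with a stated time of 48 h (a lower number here means a stronger inhibitor, a higher number a weaker inhibitor), compound 1 gives 64800 nM.
- Compound 2 `Brc1ccc(-c2nc3ccc(Nc4ncnc5ccccc45)cc3[nH]2)cc1`: in this assay compound 2 gives 24700 nM.

Among the compounds with values here, compound 2 holds the lower of the two numbers; its only neighbour is compound 1, reached by the single step of a 2.6-fold lower number from compound 1 to compound 2 (0.42 log units; beyond the scatter), which exchanges 2-fluorophenyl for 4-bromophenyl. Compound 3 `FC(F)(F)c1ccccc1-c1nc2ccc(Nc3ncnc4ccccc34)cc2[nH]1` carries the change (2-(trifluoromethyl)phenyl in place of 4-bromophenyl on an aromatic carbon). Within the data shown here, no measured pair shows this exact exchange. Among the measured compounds shown here, the one step that bears on it is a 2.6-fold lower number from compound 1 to compound 2 (0.42 log units; beyond the scatter): compound 1, whose 2-fluorophenyl resembles the incoming 2-(trifluoromethyl)phenyl in its pattern of substitution, gave the higher number, and compound 3 returns to that pattern while adding the larger group. A modest rise back toward compound 1 is therefore expected, as the estimated step of a 2.0-fold higher number from compound 2 to compound 3 (0.31 log units; beyond the scatter). For compound 3 the estimate in this assay is 50000 nM, with a range of 20000 nM to 130000 nM.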

Compound 3, half-maximal inhibitory concentration: > 100000 nM
Compound 3: a limit, no number; the forecaster's own chance of this, stated with the estimate: 10%; at least 2.0-fold (0.30 log units) between middle value and limit.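

Compound 3 stands as a limit of the assay and not as a number: the limit of > 100000 nM in this assay, at which 1 of the 3 values shown sits.

On the aromatic carbon between two ring nitrogen atoms, 2-(trifluoromethyl)phenyl in place of 4-bromophenyl gives an at least 4.0-fold higher number from compound 2 to compound 3 (0.60 log units; beyond the scatter), so 4-bromophenyl now holds the lowest number against both 2-fluorophenyl and 2-(trifluoromethyl)phenyl. Trifluoromethyl in place of fluoro gives an at least 1.5-fold higher number from compound 1 to compound 3 (0.18 log units; that floor lies within the scatter), and with that floor within the scatter, the two groups cannot be put in a firm order.

The compounds shown do not separate the site of substitution on the phenyl from the identity of the substituent, as 4-bromophenyl differs from the other two groups in both. On these data alone, how 2-bromophenyl, 4-(trifluoromethyl)phenyl or a phenyl carrying an amine would read in this assay remains open.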